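Swapping Methoxy for Dimethylamino on a Chemokine Receptor Antagonist

This account rests on a few compounds, and the source may have more. Where it says the series, first, only, none or still open, it means among the compounds named here.

Compound 1 `COc1nn(CC(N)=O)c2ncnc(NS(=O)(=O)c3cccc(Cl)c3Cl)c12` gives 501 nM in a functional assay on cells for antagonist activity at C-C chemokine receptor type 4 (Homo sapiens), read by GTPgammaS binding; a higher number here means a weaker inhibitor, a lower number a stronger inhibitor.
Compound 2 `COCCn1nc(OC)c2c(NS(=O)(=O)c3cccc(Cl)c3Cl)ncnc21` gives 316 nM in this assay.

Only these two numbers exist, and compound 2 cannot be set apart from compound 1, because a 1.6-fold lower number from compound 1 to compound 2 (0.20 log units; within the scatter). The new compound, compound 3 `COc1nn(CCN(C)C)c2ncnc(NS(=O)(=O)c3cccc(Cl)c3Cl)c12`, differs from compound 2 in one place: dimethylamino in place of methoxy on a saturated chain carbon, two bonds along the chain from an aromatic nitrogen. Among the compounds with values here, the one measured step, from compound 1 to compound 2, also reworked the end of the chain on the aromatic nitrogen, and it stayed inside the scatter, so it gives little reason to expect a large move here. The expectation is therefore a step of about a 1.3-fold lower number from compound 2 to compound 3 (0.10 log units; within the scatter) in this assay, with no confident direction. For compound 3 the estimated value in this assay is 250 nM, expected to lie between 80 nM and 800 nM.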

Compound 3, half-maximal inhibitory concentration: 3980 nM
Compound 3: middle estimate off by 16-fold (1.20 log units), on the low side; measured number above the stated range.
By their numbers in this assay, from the lowest: compounds 2 and 1 (each within the scatter of the next); then compound 3.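

The end of this chain matters more than the first two compounds suggested: carbamoyl and methoxymethyl could not be told apart, but in this assay dimethylamino in place of methoxy gives a 13-fold higher number from compound 2 to compound 3 (1.10 log units; beyond the scatter) and so a clearly weaker inhibitor. Set against the carbamoyl end, the change also gives a 7.9-fold higher number from compound 1 to compound 3 (0.90 log units; beyond the scatter) and stays beyond the scatter, so compound 3 falls behind both earlier compounds, not just one. No measurement shown here explains this loss.

Still open, as far as these compounds go, is whether the loss belongs to dimethylamino alone or would also appear with a primary amine, a morpholine or a carboxylic acid at the end of the chain. Equally open, from the compounds shown here alone, is whether a longer chain carrying the same dimethylamino group would recover any of the lost activity.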